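Benzyl replacement carried over to a second core

The source may report more compounds than this note shows. Statements on the series, on what has been measured and on what is new or still open speak of the compounds shown alone.

Measured compounds:
compound 1 `Cc1ccc(CC(CN/C(S)=N/Cc2ccc(NS(C)(=O)=O)cc2)COC(=O)c2ccccc2)cc1C`: 410 nM
compound 2 `CC(C)(C)c1ccc(CC(CN/C(S)=N/Cc2ccc(NS(C)(=O)=O)cc2)COC(=O)c2ccccc2)cc1`: 239 nM
compound 3 `COc1cc(C/N=C(\S)NCC(COC(=O)C(C)(C)C)Cc2ccc(C)c(C)c2)ccc1NS(C)(=O)=O`: 49 nM

Compounds 1 and 2 share one core; compound 3 carries another, and the difference between the two cores is not broken down here. In an assay on isolated protein for binding affinity to transient receptor potential cation channel subfamily V member 1 (Rattus norvegicus) (on this read-out lower numbers stand for stronger inhibition and higher numbers for weaker inhibition), compound 1 gives 410 nM and compound 2 gives 239 nM. The change between them is 4-(tert-butyl)phenyl in place of 3,4-dimethylphenyl on a saturated chain carbon, three bonds along the chain from an amine nitrogen and an oxygen next to a carbonyl group, and it made a step of a 1.7-fold lower number from compound 1 to compound 2 (0.23 log units; within the scatter). Compound 3 gives 49 nM in this assay, the lowest number of the three, with both other compounds beyond the scatter from it.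

Compound 4 `COc1cc(C/N=C(\S)NCC(COC(=O)C(C)(C)C)Cc2ccc(C(C)(C)C)cc2)ccc1NS(C)(=O)=O` is not yet measured. It differs from compound 3 by 4-(tert-butyl)phenyl in place of 3,4-dimethylphenyl on a saturated chain carbon, three bonds along the chain from an amine nitrogen and an oxygen next to a carbonyl group, the same change seen on the first core, made at the same place. Only one prior occurrence exists, so the expectation rests on that single step and on the value of compound 3. Because the earlier occurrence gave a 1.7-fold lower number from compound 1 to compound 2 (0.23 log units; within the scatter), compound 4 is expected in this assay to give about 32 nM, within roughly 12 nM to 80 nM. The estimated step is a 1.5-fold lower number from compound 3 to compound 4 (0.19 log units; within the scatter), a small one that may well fall within the scatter.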

Compound 4, inhibition constant: 25.2 nM
Compound 4: middle estimate off by 1.3-fold (0.10 log units), on the high side, and the stated range covers the measured number.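

In this assay, replacing 3,4-dimethylbenzyl with 4-(tert-butyl)benzyl gives a 1.9-fold lower number from compound 3 to compound 4 (0.29 log units; within the scatter), and this step agrees with the one on the first core: the same change on two cores in this assay, a 1.7-fold lower number (0.23 log units; within the scatter) from compound 1 to compound 2 and a 1.9-fold lower number (0.29 log units; within the scatter) from compound 3 to compound 4, 1.1-fold (0.05 log units) apart, within the scatter of two such steps. The change therefore reads the same on the core of compound 1 and the core of compound 3, and these two pairs give no sign that the core alters its outcome. This does not show that the change has a real effect on either core, as each step lies within the scatter, and two cores are too few to support a rule for the whole series.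

Open, on these data alone, is whether the agreement would hold for a benzyl group of another kind, such as an unsubstituted benzyl or a 4-chlorobenzyl, particularly if the step were to lie beyond the scatter. Also open, as far as these compounds go, is whether it would survive on a core with an amide in place of the ester.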